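Swapping a Pyridine Ring for a Chlorophenyl on an Ester

The compounds below may be only part of what the source reports. "The series", "measured", "known", "first", "only" and "open" are said of these compounds alone.

Of the compounds shown here, three built on one shared core have been tested in a functional assay on MDA-MB-231 cells (Homo sapiens) for antiproliferative activity, read by MTT assay, with a stated time of 72 h; a higher number here means a weaker inhibitor, a lower number a stronger inhibitor. Compound 1 `CC1=CC[C@H]2[C@H](CC[C@]2(C)O)C(C)(C)[C@@H]1CC[C@H]1[C@]2(C)CC[C@H](OC(=O)c3ccncc3)C(C)(C)O[C@H]2CC[C@@]1(C)O` gives 18000 nM. Compound 2 `CC1=CC[C@H]2[C@@H]1CC=C(C)[C@@H](CC[C@H]1[C@]3(C)CC[C@H](OCc4ccccc4)C(C)(C)O[C@H]3CC[C@@]1(C)O)C2(C)C` gives 35700 nM, and compound 3 `CC1=CC[C@H]2[C@H](CC[C@]2(C)O)C(C)(C)[C@@H]1CC[C@H]1[C@]2(C)CC/C(=N/OC(=O)c3ccccc3)C(C)(C)O[C@H]2CC[C@@]1(C)O` gives 27400 nM. Compound 1 has the lowest of the three numbers, yet its gaps to compound 3 and to compound 2 both lie within the usual scatter of repeated measurements of this kind, so no order among the three can be read from these values.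

Compound 4 `CC1=CC[C@H]2[C@H](CC[C@]2(C)O)C(C)(C)[C@@H]1CC[C@H]1[C@]2(C)CC[C@H](OC(=O)c3ccccc3Cl)C(C)(C)O[C@H]2CC[C@@]1(C)O` has not yet been measured. It differs from compound 1 in a single place: 2-chlorophenyl in place of pyridin-4-yl on a carbonyl carbon. Within the data shown here, no pair of measured compounds differs by this kind of change alone, so there is nothing to set the change directly against. What the measured values do show is that all three sit close together, which gives no sign that this part of the molecule moves the number far.

On that basis the expected step of a 1.2-fold lower number from compound 1 to compound 4 (0.08 log units; within the scatter) is no larger than the scatter, in either direction. Compound 4 is expected to give about 15000 nM in this assay, with a range from 6000 nM to 40000 nM.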

Compound 4, half-maximal inhibitory concentration: 24300 nM
Compound 4: the middle estimate sits 1.6-fold (0.21 log units) below what was measured; the range from low to high includes it.
By their numbers in this assay, from the lowest: compounds 1, 4, 3 and 2 (each within the scatter of the next).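

In this assay, among these compounds, putting 2-chlorophenyl in place of pyridin-4-yl on the carbonyl carbon gives a 1.4-fold higher number from compound 1 to compound 4 (0.13 log units; within the scatter), the first direct reading of a single change at this place. The ring nitrogen leaves and a chlorine enters, yet the step stays within the scatter, so this swap of one aromatic ring for another shows no measurable change in the number. Nothing measured here explains why the two compounds read alike.

Still open, as far as these compounds go, is whether a group of another kind on this carbonyl carbon, such as a plain methyl, a longer alkyl chain or a chain ending in an amine, would shift the number beyond the scatter. Also open, from the compounds shown here alone, is whether an amide link in place of the ester would do so.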